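Changing the amine group on the side chain

The source may report more compounds than this note shows. Statements on the series, on what has been measured and on what is new or still open speak of the compounds shown alone.

compound 1 `COc1cc2oc(-c3ccccc3)cc(=O)c2c(O)c1OCCCCN1CCN(C)CC1`: 53500 nM
compound 2 `CN1CCN(CCCCOc2c(O)cc3oc(-c4ccccc4)cc(=O)c3c2O)CC1`: 82900 nM

Both values come from a functional assay on BCG823 cells (Homo sapiens) for antiproliferative activity, read by MTT assay, with a stated time of 48 h; on this read-out lower numbers stand for stronger inhibition and higher numbers for weaker inhibition. For the measured compounds named here, only one step has been measured: a 1.5-fold higher number from compound 1 to compound 2 (0.19 log units; within the scatter). Going by the values given here, on these numbers, compound 2 cannot be told apart from the only other measured compound.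

Compound 3 `O=c1cc(-c2ccccc2)oc2cc(O)c(OCCCN3CCCC3)c(O)c12` differs from compound 2 on the side chain: pyrrolidin-1-yl in place of (4-methylpiperazin-1-yl)methyl on a saturated chain carbon, three bonds along the chain from an oxygen on an aromatic ring. The measured step, hydrogen in place of methyl on an oxygen on an aromatic ring, changed a different part of the molecule and gives no direct guide here. With no direction indicated, no change beyond the scatter is expected in this assay. The expected step is a 1.4-fold lower number from compound 2 to compound 3 (0.14 log units; within the scatter). Compound 3 is expected at 60000 nM, within an estimated range of 20000 nM to 150000 nM.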

Compound 3, half-maximal inhibitory concentration: > 100000 nM
Compound 3: a limit, no number (the forecaster's own chance of this, stated with the estimate: 10%); at least 1.6-fold (0.22 log units) between middle value and limit.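

For the compounds shown here, this is the first change to the side chain itself: 3-(4-methylpiperazin-1-yl)propyl gives way to 2-(pyrrolidin-1-yl)ethyl, so ring and chain differ together. Compound 3 sits at a limit of the assay, which is not a number: the limit of > 100000 nM in this assay, at which 1 of the 3 values shown sits. As far as these compounds go, the step is an at least 1.2-fold higher number from compound 2 to compound 3 (0.08 log units; that floor lies within the scatter), so in this assay this swap gave no lower number, and the true size of the step stays unknown.

The compounds shown leave open whether the ring or the chain length counts here. A morpholine ring on the butyl chain, or pyrrolidine on a butyl chain, would separate the two.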